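The source may hold more compounds than are shown below. What is called first, only, known or untested is meant among the compounds shown, and "the series" means these compounds.

Compound 1 `O=C(Nc1ccc(Cl)cc1)N1CCC[C@H]1c1nc(-c2ccccc2F)no1`: > 50000 nM
Compound 2 `O=C(Nc1ccc(Cl)cc1)N1CCC[C@H]1c1nc(-c2cccc(F)c2)no1`: > 50000 nM

In an ADME assay on MCF-10A cells (Homo sapiens) for inhibition, with a stated time of 48 h (a higher number here means a weaker inhibitor, a lower number a stronger inhibitor), compound 2 gives > 50000 nM, which is a limit of the assay and not a number. Neither measured compound yields more than that: the limit of > 50000 nM in this assay, at which 2 of the 2 values shown sit. Compound 3 `Cc1ccc(-c2noc([C@@H]3CCCN3C(=O)Nc3ccc(Cl)cc3)n2)cc1` changes one group on the shared core: 4-methylphenyl in place of 3-fluorophenyl on an aromatic carbon. Going by the values given here, the one measured step that bears on this, a step that the two limits leave unreadable from compound 1 to compound 2, offers no readable size. With no size to carry over, no step beyond the scatter is expected. The estimated step is a number no higher from compound 2 to compound 3 (the limit leaves the size open). Compound 3 is expected at 50000 nM, within an estimated range of 20000 nM to 100000 nM.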

Compound 3, half-maximal inhibitory concentration: > 50000 nM
Compound 3 ended at the assay's limit (the forecaster's own chance of this, stated with the estimate: 80%); the middle value sits exactly at the limit.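

Compound 3 gives > 50000 nM, which is a limit and not a number, so neither the step from compound 1 nor the step from compound 2 to it can be read. The compounds shown leave open whether any of these changes on the shared core alters inhibition, with every value at one limit: the limit of > 50000 nM in this assay, at which 3 of the 3 values shown sit.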